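A 4-propylpiperazin-1-yl group exchanged in compound 2

A few compounds are considered here, and "the series" means these few. Any claim that something is new, unique, unknown or untested is made for them only; others in the source may bear on it.

In a functional assay on A549 cells (Homo sapiens) for cytotoxicity, read by MTT assay, with a stated time of 72 h (on this read-out higher numbers stand for weaker inhibition and lower numbers for stronger inhibition), compound 1 (`CN1CCN(CCCCn2c3c(c4ccccc42)C(=O)c2c[n+]([O-])c4ccccc4c2C3=O)CC1`) gives 90 nM, and compound 2 (`CCCN1CCN(CCCCn2c3c(c4ccccc42)C(=O)c2c[n+]([O-])c4ccccc4c2C3=O)CC1`) gives 320 nM, the higher of the two numbers. Compound 3 (`CN1CCN(CCCCCCn2c3c(c4ccccc42)C(=O)c2c[n+]([O-])c4ccccc4c2C3=O)CC1`) has the same atoms as compound 2, joined differently: 2-(4-methylpiperazin-1-yl)ethyl in place of 4-propylpiperazin-1-yl on a saturated chain carbon, four bonds along the chain from an aromatic nitrogen. Within the data shown here, only one measured step bears on this change: a 3.6-fold higher number from compound 1 to compound 2 (0.55 log units; beyond the scatter). Compound 3 shares its methylpiperazine end with compound 1, which gives 90 nM, but the effect of the longer chain has not been measured. A partial return towards that number is therefore expected, as a small step to a lower number in this assay that may not clear the scatter. The expected step is a 1.8-fold lower number from compound 2 to compound 3 (0.25 log units; within the scatter). The estimate for compound 3 is 180 nM, with an expected range of 60 nM to 500 nM.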

Compound 3, half-maximal inhibitory concentration: 330 nM
Compound 3: the middle estimate sits 1.8-fold (0.26 log units) below what was measured; measured number inside the range.
By their numbers in this assay, from the lowest: compound 1; then compounds 2 and 3 (each within the scatter of the next).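

In this assay, the same atoms placed in the chain rather than on the far piperazine nitrogen give no separable change: a 1.0-fold higher number from compound 2 to compound 3 (0.01 log units; within the scatter). With the methylpiperazine end kept, 2-(4-methylpiperazin-1-yl)ethyl in place of 4-methylpiperazin-1-yl gives a 3.7-fold higher number from compound 1 to compound 3 (0.56 log units; beyond the scatter), so the longer chain alone produces a step of much the same size as the propyl group in a 3.6-fold higher number from compound 1 to compound 2 (0.55 log units; beyond the scatter), and the methyl end does not by itself preserve the number of compound 1. Nothing available explains either step.

Still open, from the compounds shown here alone, is how a shorter chain would read in this assay, and whether the trend continues in either direction along the chain. Going by these compounds, it is also open whether a propyl group on the piperazine adds to the longer chain, or how a morpholine would compare with the piperazine.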